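The compounds below may be only part of what the source reports. "The series", "measured", "known", "first", "only" and "open" are said of these compounds alone.

Compound 2 `C[C@H](NC(=O)C(=O)NCc1ccccc1F)C(=O)N[C@@H](CC(=O)O)C(=O)COc1c(F)c(F)cc(F)c1F` gives 207 nM in a functional assay on Jurkat cells (Homo sapiens) (a lower number here means a stronger inhibitor, a higher number a weaker inhibitor), the highest of the three numbers measured, though it sits within the scatter of compound 3. Compound 1 `Cc1ccccc1CNC(=O)C(=O)N[C@@H](C)C(=O)N[C@@H](CC(=O)O)C(=O)COc1c(F)c(F)cc(F)c1F` gives 52 nM, and compound 3 `C[C@H](NC(=O)C(=O)NCc1ccc(Cl)cc1Cl)C(=O)N[C@@H](CC(=O)O)C(=O)COc1c(F)c(F)cc(F)c1F` gives 165 nM. The step of a 4.0-fold higher number from compound 1 to compound 2 (0.60 log units; beyond the scatter) and the step of a 3.2-fold higher number from compound 1 to compound 3 (0.50 log units; beyond the scatter) were both modest, while the step of a 1.3-fold lower number from compound 2 to compound 3 (0.10 log units; within the scatter) stayed within the scatter. Compound 4 `C[C@H](NC(=O)C(=O)NCc1cc(Cl)cc(Cl)c1)C(=O)N[C@@H](CC(=O)O)C(=O)COc1c(F)c(F)cc(F)c1F` differs from compound 2 by 3,5-dichlorophenyl in place of 2-fluorophenyl on a saturated chain carbon bound to an amide-type nitrogen. The step from compound 2 to compound 3, which likewise exchanged 2-fluorophenyl for 2,4-dichlorophenyl at the same place, bears most directly on this; a step within the scatter of this assay is therefore expected, with no clear direction. Compound 4 is estimated at 170 nM, with a range of 70 nM to 420 nM, which means an expected step of a 1.2-fold lower number from compound 2 to compound 4 (0.09 log units; within the scatter).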

Compound 4, half-maximal inhibitory concentration: 23 nM
Compound 4: middle estimate off by 7.4-fold (0.87 log units), on the high side; the measured number lies below the stated range.
By their numbers in this assay, from the lowest: compound 4; then compound 1; then compounds 3 and 2 (each within the scatter of the next).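

The placing of the two chlorines on the phenyl group matters at this position, not just their presence: moving from 2,4-dichlorophenyl to 3,5-dichlorophenyl gives a 7.2-fold lower number from compound 3 to compound 4 (0.86 log units; beyond the scatter), although 2,4-dichlorophenyl had shown no step beyond the scatter against 2-fluorophenyl. The new group also gives a 9.0-fold lower number from compound 2 to compound 4 (0.95 log units; beyond the scatter), and even against 2-methylphenyl it gives a 2.3-fold lower number from compound 1 to compound 4 (0.35 log units; beyond the scatter), which leaves compound 4 with the lowest number in this assay.

The compounds shown offer no measured reason for this difference. From the compounds shown here alone, it remains open whether a single 3-chlorophenyl or a 3,5-dimethylphenyl group would match compound 4.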